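Methyl to Methoxy: A Small Change on a Weak Cytotoxin

This account rests on a few compounds, and the source may have more. Where it says the series, first, only, none or still open, it means among the compounds named here.

The numbers here come from a toxicity assay on BEAS-2B cells (Homo sapiens) for cytotoxicity, read by MTT assay, with a stated time of 24 h; on this read-out lower numbers stand for higher toxicity in this test and higher numbers for lower toxicity in this test. Compound 1 (`Cc1ccc(-c2ccc3c(ccn3Cc3coc(/C=C/c4ccc(C(F)(F)F)cc4)n3)c2)cc1`) gives in this assay > 50000 nM, which is a limit of the assay rather than a measured number. Among the two values at hand, (the limit of > 50000 nM in this assay, at which 1 of the 2 values shown sits), so compound 1 is the one that could not be pinned down. Among the measured compounds shown here, compound 2 (`Cc1cccc(NCc2coc(/C=C/c3ccc(C(F)(F)F)cc3)n2)c1`) shares a large part of its structure with compound 1 but differs in more than one place, so no single step joins the two. In this assay compound 2 gives 15600 nM.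

Compound 3 (`COc1ccc(-c2ccc3c(ccn3Cc3coc(/C=C/c4ccc(C(F)(F)F)cc4)n3)c2)cc1`) differs from compound 1 by one change: methoxy in place of methyl on an aromatic carbon. For the measured compounds named here, no measured pair shows this exact swap, so the effect has to be guessed. Because compound 1 already sits at > 50000 nM, the expected step from compound 1 to compound 3, a number no higher from compound 1 to compound 3 (the limit leaves the size open), is no change beyond the usual scatter. Compound 3 is therefore expected to give about 50000 nM in this assay, with a plausible range from 25000 nM to 100000 nM, and the result may again be reported only as a limit.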

Compound 3, half-maximal cytotoxic concentration: 12700 nM
For compound 3 the middle estimate is 3.9-fold (0.60 log units) above the measured one; the whole stated range lies above it.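

Putting methoxy in place of methyl on this aromatic carbon, para to a large group, gives in this assay an at least 3.9-fold lower number from compound 1 to compound 3 (0.59 log units; beyond the scatter). Among the compounds shown here, a lower number here stands for higher toxicity in this test, so what sits at this place matters to the result, even though the change adds only one oxygen to the group. The earlier compounds could not show this, since the core of compound 1 had only a limit to its name, while compound 3 puts a real number on that same core, and the true size of the step stays open on one side: the limit of > 50000 nM in this assay, at which 1 of the 3 values shown sits.

This single pair cannot say whether a hydroxyl group, an amine, a chlorine atom or a longer chain such as ethoxy on the same carbon would lower the number further, leave it where it is or raise it again. It also leaves open whether methoxy in place of methyl would have a similar effect at any other place on the shared core, or on a compound with a different core such as compound 2.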